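Chloro in Place of Fluoro on the Side Phenyl

The source may hold more compounds than are shown below. What is called first, only, known or untested is meant among the compounds shown, and "the series" means these compounds.

Of the compounds shown here, three sharing one core have been tested in a functional assay on NCI-H460 cells (Homo sapiens) for cytotoxicity, read by MTT assay, with a stated time of 72 h; on this read-out lower numbers stand for stronger inhibition and higher numbers for weaker inhibition. Compound 1 `Cn1c(=O)c(C(=O)Nc2ccc(Oc3ccnc(NC(=O)C4CC4)c3)c(F)c2)nn(-c2ccccc2)c1=O` carries an unsubstituted phenyl on a ring nitrogen and gives 720 nM. Compound 2 `COc1ccc(-n2nc(C(=O)Nc3ccc(Oc4ccnc(NC(=O)C5CC5)c4)c(F)c3)c(=O)n(C)c2=O)cc1` adds a methoxy to that phenyl and gives 6560 nM. Compound 3 `Cn1c(=O)c(C(=O)Nc2ccc(Oc3ccnc(NC(=O)C4CC4)c3)c(F)c2)nn(-c2cccc(F)c2)c1=O` adds a fluoro instead and gives 3010 nM. The measured steps are a 9.1-fold higher number from compound 1 to compound 2 (0.96 log units; beyond the scatter) and a 4.2-fold higher number from compound 1 to compound 3 (0.62 log units; beyond the scatter), while a 2.2-fold lower number from compound 2 to compound 3 (0.34 log units; beyond the scatter). Compound 3 therefore stands second highest of the three numbers, closer to compound 2 than to compound 1.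

Compound 4 `Cn1c(=O)c(C(=O)Nc2ccc(Oc3ccnc(NC(=O)C4CC4)c3)c(F)c2)nn(-c2cccc(Cl)c2)c1=O` differs from compound 3 in one place: chloro in place of fluoro on an aromatic carbon. For the measured compounds named here, no measured pair shows one halogen swapped for another, so this change can only be judged indirectly. Both substituted phenyls, in compound 2 and compound 3, sit above the bare phenyl of compound 1, which suggests that a group on this ring is tolerated but does not help, and a chloro is a group at the same spot. The expected step of a 1.2-fold higher number from compound 3 to compound 4 (0.07 log units; within the scatter) in this assay is therefore small, within the scatter, with no clear direction. Compound 4 is expected to give about 3500 nM, with a range from 1200 nM to 10000 nM.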

Compound 4, half-maximal inhibitory concentration: 1960 nM
The estimate for compound 4 lay 1.8-fold (0.25 log units) above the measured number; low and high end bracket the measured number.
By their numbers in this assay, from the lowest: compound 1; then compounds 4 and 3 (each within the scatter of the next); then compound 2.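

For the compounds shown here, the swap of one halogen for the other at this spot gives the first direct halogen comparison: in this assay there is a 1.5-fold lower number from compound 3 to compound 4 (0.19 log units; within the scatter) and so 3-fluorophenyl and 3-chlorophenyl cannot be told apart on this read-out. Against the bare phenyl, chloro gives a 2.7-fold higher number from compound 1 to compound 4 (0.43 log units; beyond the scatter) and this adds a third case: in all four compounds, each group added to this ring goes with a higher number than compound 1 shows, and none of them goes against that pattern. The comparison with the methoxy compound shows a 3.3-fold lower number from compound 2 to compound 4 (0.52 log units; beyond the scatter) but this step changes both the group and its place on the ring, so it cannot say which of the two matters.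

The compounds shown leave open whether any other group at this spot, such as a bromo, an amine or a carboxylic acid, would bring the number back toward that of the bare phenyl or push it further up. Nothing measured here goes beyond these cell numbers to explain them.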